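This account rests on a few compounds, and the source may have more. Where it says the series, first, only, none or still open, it means among the compounds named here.

In an in vitro assay on BTI-TN-5B1-4 cells for inhibition of sterol O-acyltransferase 2 (Homo sapiens), tested at 50 uM (on this read-out lower numbers stand for less inhibition and higher numbers for more inhibition at the one concentration tested (going by the name of the read-out)), compound 1 `CCCCCCCC(=O)Nc1ccc(-c2ccccc2)cc1` gives 11%, and compound 2 `CCCCCCCCC(=O)Nc1ccc(-c2ccccc2)cc1` gives 20%. The change between them, (methyl in place of hydrogen on a saturated chain carbon, seven bonds along the chain from a carbonyl carbon), made a step of a number 9 percentage points higher from compound 1 to compound 2 (within the scatter). Compound 3 `CCCCCCCCNc1cccc(-c2ccccc2)c1` is built on a different core; the difference between the two cores is not broken down here. In this assay compound 3 gives -20%, the lowest of the three numbers. Compound 4 `CCCCCCCCCNc1cccc(-c2ccccc2)c1` has not yet been measured. It differs from compound 3 by methyl in place of hydrogen on a saturated chain carbon, eight bonds along the chain from a nitrogen on an aromatic ring. Going by the values given here, this is the same kind of change as the one from compound 1 to compound 2, but here the chain is counted eight bonds along from a nitrogen on an aromatic ring rather than seven bonds along from a carbonyl carbon. Because the earlier step of a number 9 percentage points higher from compound 1 to compound 2 (within the scatter) stayed within the scatter, a similarly small movement is anticipated. Compound 4 is therefore expected to give about -12%, likely between -35% and 12%, which means an expected step of a number 8 percentage points higher from compound 3 to compound 4 (within the scatter).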

Compound 4, a percentage reported as inhibition, at one concentration (the size of the read-out at that concentration, not a potency): -8%
Compound 4: the middle estimate sits 4 percentage points below what was measured; measured number inside the range.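

In this assay, methyl in place of hydrogen on a saturated chain carbon gives a step of a number 12 percentage points higher from compound 3 to compound 4 (beyond the scatter). Set beside the same change on the other core, the step is of much the same size, so the change carries over between these two cores: the same change on two cores in this assay, a number 9 percentage points higher (within the scatter) from compound 1 to compound 2 and a number 12 percentage points higher (beyond the scatter) from compound 3 to compound 4, 3 percentage points apart, within the scatter of two such steps This rests on just two pairs, however, and it shows neither that the step would hold on a third core nor why the number moves at all.

The compounds shown leave open whether a longer chain would move the number further in the same direction. They also leave open what an amine or a carboxylic acid on the chain would do.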